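Methyl branching on the linker of the fluoro analogue

The source may report more compounds than this note shows. Statements on the series, on what has been measured and on what is new or still open speak of the compounds shown alone.

Measured values in a physicochemical assay for lipophilicity, read by HPLC, measured as octanol-water partition, at pH 7.4; on this read-out lower numbers stand for lower lipophilicity and higher numbers for higher lipophilicity:
Compound 1 `CC(C)(C)OC(=O)N1CCC(CCOC(=O)N2CCc3cc(S(C)(=O)=O)ccc32)CC1`: 3.1
Compound 2 `CC(CC1CCN(C(=O)OC(C)(C)C)CC1)OC(=O)N1CCc2cc(S(C)(=O)=O)ccc21`: 3.4
Compound 3 `CC(C)(C)OC(=O)N1CCC(CCOC(=O)N2CCc3cc(S(C)(=O)=O)cc(F)c32)CC1`: 3

Compound 3 differs from compound 1 by fluoro in place of hydrogen on an aromatic carbon, a change that gave a step of a number 0.10 log units lower from compound 1 to compound 3 (within the scatter). Compound 2 differs from compound 1 by methyl in place of hydrogen on a saturated chain carbon bound to an oxygen next to a carbonyl group and a saturated chain carbon; in this assay this gave a step of a number 0.30 log units higher from compound 1 to compound 2 (within the scatter). The not yet measured compound 4 `CC(COC(=O)N1CCc2cc(S(C)(=O)=O)cc(F)c21)C1CCN(C(=O)OC(C)(C)C)CC1` differs from compound 3 by methyl in place of hydrogen on a saturated chain carbon bound to a saturated chain carbon and a saturated ring carbon. For the measured compounds named here, this is the same kind of change as the one from compound 1 to compound 2, not the same: there the carbon carrying the new methyl is bound to an oxygen next to a carbonyl group and a saturated chain carbon, here it is bound to a saturated chain carbon and a saturated ring carbon. Going by the values given here, only one measured pair covers a methyl for hydrogen on the chain, so the expectation rests on it alone: a step of a number 0.30 log units higher from compound 3 to compound 4 (within the scatter) is expected for compound 4, set beside a number 0.30 log units higher from compound 1 to compound 2 (within the scatter) and the value of compound 3, 3. Compound 4 is therefore estimated at 3.3 in this assay, expected to lie between 3 and 3.6.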

Compound 4, distribution coefficient: 3.3
Beside the measured number, compound 4's estimate shows no gap at the digits printed; low and high end bracket the measured number.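

In this assay, methyl in place of hydrogen on a saturated chain carbon bound to a saturated chain carbon and a saturated ring carbon gives a number 0.30 log units higher from compound 3 to compound 4 (within the scatter), matching at the printed digits the earlier a number 0.30 log units higher from compound 1 to compound 2 (within the scatter). Both steps lie within the scatter, so the match shows that methyl on the chain produced no step beyond the scatter on either core, but it does not establish a real rise on either one, and it is no clean test of transfer, since the core and the carbon carrying the methyl both differ between the two pairs. Nothing at hand accounts for the size of either step.

Still open, going by these compounds, is whether the fluoro core gives a step of the same size with the methyl on the saturated chain carbon bound to an oxygen next to a carbonyl group. Also open, on these data alone, is whether a longer chain such as ethyl, or an amine, on the chain would follow the methyl steps on these cores.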